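Methyl on the ring amine: from compound 1 to compound 3

The compounds below may be only part of what the source reports. "The series", "measured", "known", "first", "only" and "open" are said of these compounds alone.

Within the data shown here, compound 1 `C[C@@H]1CN(c2cccc3c2C[C@H](CN(C)[C@H]2CCCc4cccnc42)NC3)C[C@H](C)N1` holds, in a functional assay on CCRF-CEM cells for antagonist activity at C-X-C chemokine receptor type 4 (Homo sapiens), read by calcium flux, with stated times of 25 min and 90 s (on this read-out lower numbers stand for stronger inhibition and higher numbers for weaker inhibition), the lower of the two numbers measured so far, at 61 nM. Among the measured compounds shown here, compound 2 `CC(C)N(C[C@H]1Cc2c(cccc2N2CCNCC2)CN1)[C@H]1CCCc2cccnc21` gives in this assay 364 nM; the gap to compound 1 lies beyond the scatter, but the two structures differ in more than one place, so no single step is read from that pair. Compound 3 `C[C@@H]1CN(c2cccc3c2C[C@H](CN(C)[C@H]2CCCc4cccnc42)NC3)C[C@H](C)N1C` differs from compound 1 by methyl in place of hydrogen on an amine nitrogen in a ring. For the measured compounds named here, no step of this kind has been measured, so only a small change, within the scatter and in either direction, is expected. Compound 3 is therefore estimated at 80 nM, with a range of 25 nM to 250 nM. The expected step is a 1.3-fold higher number from compound 1 to compound 3 (0.12 log units; within the scatter).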

Compound 3, half-maximal inhibitory concentration: 14.1 nM
Beside the measured number, compound 3's estimate is 5.7-fold (0.75 log units) above it, and the stated range ends above it.
By their numbers in this assay, from the lowest: compound 3; then compound 1; then compound 2.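

In this assay, methyl in place of hydrogen on this ring amine, 3,5-dimethylpiperazin-1-yl to 3,4,5-trimethylpiperazin-1-yl, gives a 4.3-fold lower number from compound 1 to compound 3 (0.64 log units; beyond the scatter). Among these compounds, this is the first single-place step, and it shows that the hydrogen on this nitrogen is not needed for inhibition in this assay. Nothing at hand accounts for the step.

Open, on these data alone, is whether an ethyl group or a longer chain on this nitrogen extends the gain or loses it. Also open, as far as these compounds go, is whether the same methyl step holds without the two neighbouring ring methyl groups.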